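Replacing 3-bromophenyl with 2,4-difluorophenyl on a shared core

The source may report more compounds than this note shows. Statements on the series, on what has been measured and on what is new or still open speak of the compounds shown alone.

Measured so far in a functional assay on HepG2 cells (Homo sapiens) for inhibition, read by MTT assay, with a stated time of 48 h; a higher number here means a weaker inhibitor, a lower number a stronger inhibitor:
Compound 1 (`Fc1ccccc1CSc1nnc(-c2ccncc2)n1-c1ccccc1`): > 50000 nM (a limit)
Compound 2 (`Brc1ccccc1CSc1nnc(-c2ccncc2)n1-c1ccccc1`): 17100 nM
Compound 3 (`Brc1cccc(CSc2nnc(-c3ccncc3)n2-c2ccccc2)c1`): 7040 nM

Compound 3 has the lowest number shown, at 7040 nM, and so is the strongest inhibitor of the three. Compound 2 is its nearest neighbour, and a 2.4-fold lower number from compound 2 to compound 3 (0.39 log units; beyond the scatter) is a modest step. Compound 1 is reported only as a limit, > 50000 nM, and not as a number.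

Compound 4 (`Fc1ccc(CSc2nnc(-c3ccncc3)n2-c2ccccc2)c(F)c1`) has 2,4-difluorophenyl in place of the 3-bromophenyl of compound 3, on a saturated chain carbon bound to a sulfur (2,4-difluorophenyl in place of 3-bromophenyl on a saturated chain carbon bound to a sulfur). Among the measured compounds shown here, no measured compound carries this group, so the nearest evidence comes from compound 1, the only fluorinated compound measured. Two steps away from it bear on the change: an at least 2.9-fold lower number from compound 1 to compound 2 (0.46 log units; beyond the scatter) with bromo in place of fluoro, and an at least 7.1-fold lower number from compound 1 to compound 3 (0.85 log units; beyond the scatter) with 3-bromophenyl in place of 2-fluorophenyl. Run in reverse, these steps lead to the expectation of a higher number, and thus a weaker inhibitor, of at least modest size. The expected change is a 4.3-fold higher number from compound 3 to compound 4 (0.63 log units; beyond the scatter) in this assay, and compound 4 could also end up as a limit. For compound 4 the estimated value is 30000 nM, with an expected range from 12000 nM to 70000 nM.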

Compound 4, half-maximal inhibitory concentration: 10200 nM
Estimate against measurement, compound 4: 2.9-fold (0.47 log units) above; measured number below the stated range.
By their numbers in this assay, from the lowest: compounds 3, 4 and 2 (each within the scatter of the next, the first and the last beyond it). At a limit, above all of these: compound 1.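

In this assay the 2,4-difluorophenyl group on a saturated chain carbon bound to a sulfur cannot be told apart from either bromophenyl group, with a 1.4-fold higher number from compound 3 to compound 4 (0.16 log units; within the scatter) and with a 1.7-fold lower number from compound 2 to compound 4 (0.22 log units; within the scatter) as the two readings. Bromine is therefore not required to reach this range of values, as compound 4 carries only fluorine on that ring, while compound 1 goes against any simple link between fluorine and a high number; fluoro in place of hydrogen on an aromatic carbon gives an at least 4.9-fold lower number from compound 1 to compound 4 (0.69 log units; beyond the scatter) as the one direct comparison. Going by these compounds, compound 1 is reported only as a limit and not as a number, so the true size of that step stays unknown: the limit of > 50000 nM in this assay, at which 1 of the 4 values shown sits.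

What the compounds shown leave open is whether a chloro, methoxy or trifluoromethyl group on this ring would fall outside this narrow group of values. On these data alone, it also remains open whether an amine or a carboxylic acid on the ring, or a longer chain in place of the saturated chain carbon bound to a sulfur, would give a clearly lower number than compound 3 with 7040 nM in this assay's terms.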